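This account rests on a few compounds, and the source may have more. Where it says the series, first, only, none or still open, it means among the compounds named here.

Compound 1 `COc1ccccc1-n1nncc1CN1C(=O)C2(C(C#N)=C(N)Oc3c2c2nc4ccccc4nc2c2ccccc32)c2ccccc21`: > 50000 nM
Compound 2 `N#CC1=C(N)Oc2c(N)cc3nc4ccccc4nc3c2C12C(=O)N(Cc1cnnn1-c1ccccc1Br)c1ccccc12`: 27400 nM

In a functional assay on A549 cells (Homo sapiens) for antiproliferative activity, read by MTT assay, with a stated time of 48 h (on this read-out lower numbers stand for stronger inhibition and higher numbers for weaker inhibition), compound 1 gives > 50000 nM, which is a limit of the assay rather than a number. In this assay compound 2 gives 27400 nM; this is the only number shown, since (the limit of > 50000 nM in this assay, at which 1 of the 2 values shown sits). Within the data shown here, compound 2 therefore stands as the one compound with a measured concentration, with nothing to compare it against beyond a limit.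

Compound 3 `Cc1ccc(C)c(-n2nncc2CN2C(=O)C3(C(C#N)=C(N)Oc4c(N)cc5nc6ccccc6nc5c43)c3ccccc32)c1` has not yet been measured in this assay. It differs from compound 2 in one place: 2,5-dimethylphenyl in place of 2-bromophenyl on an aromatic nitrogen. Among the measured compounds shown here, no step between two measured compounds is available, so there is nothing to say how such a swap has moved the numbers before. Without that, no step beyond the usual scatter is expected in either direction. Compound 3 is expected to give about 27000 nM, within 9000 nM to 80000 nM. The expected step is a 1.0-fold lower number from compound 2 to compound 3 (0.01 log units; within the scatter).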

Compound 3, half-maximal inhibitory concentration: > 50000 nM
Compound 3 gave a limit, no number; the forecaster's own chance of this, stated with the estimate: 30%; at least 1.8-fold (0.26 log units) between middle value and limit.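

Placing 2,5-dimethylphenyl in place of 2-bromophenyl on an aromatic nitrogen gives the first step that can be read at this position in this assay: an at least 1.8-fold higher number from compound 2 to compound 3 (0.26 log units; that floor lies within the scatter). Compound 3 gives > 50000 nM, which is a limit of the assay and not a number. The swap therefore brings no gain, but it cannot be called a true loss either, and compound 2 remains the only compound here with a measured concentration: the limit of > 50000 nM in this assay, at which 2 of the 3 values shown sit.

On these data alone, what remains open is how far compound 3 lies past its limit, and whether the single bromine or the two methyl groups matter on their own. A plain phenyl, or a phenyl carrying an amine, at this position would help to show whether the number can move in either direction.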